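A few compounds are considered here, and "the series" means these few. Any claim that something is new, unique, unknown or untested is made for them only; others in the source may bear on it.

Of the compounds shown here, three built on one shared core have been tested in an assay on CHO cells for displacement of a labelled ligand from Substance-P receptor (Homo sapiens); on this read-out higher numbers stand for weaker inhibition and lower numbers for stronger inhibition. Compound 1 `COc1ccccc1N1CCN(C(=O)CCc2c(-c3ccccc3Br)[nH]c3ccc(C)cc23)CC1` gives 89 nM, and compound 2 `COc1ccccc1-c1[nH]c2ccc(C)cc2c1CCC(=O)N1CCN(c2ccccc2OC)CC1` gives 82 nM; the step of a 1.1-fold lower number from compound 1 to compound 2 (0.04 log units; within the scatter) leaves the two at a similar level. Compound 3 `COc1ccccc1N1CCN(C(=O)CCc2c(-c3ccc(Cl)cc3)[nH]c3ccc(C)cc23)CC1` gives 0.6 nM, the lowest of the three numbers, and the steps of a 150-fold lower number from compound 1 to compound 3 (2.17 log units; beyond the scatter) and a 140-fold lower number from compound 2 to compound 3 (2.14 log units; beyond the scatter) are both far beyond the scatter.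

Compound 4 `COc1ccccc1N1CCN(C(=O)CCc2c(-c3ccc(-c4ccccc4)cc3)[nH]c3ccc(C)cc23)CC1` has not yet been measured. It differs from compound 3 by phenyl in place of chloro on an aromatic carbon. The two large measured steps show that the group carried on that aromatic carbon of the core can move the number by a great deal, but both of them change a different aryl into the 4-chlorophenyl of compound 3; none of them tests what happens when the chloro itself is replaced, so they bear on this change only indirectly. A step of some size in either direction is possible, with a modest weakening judged most likely. Compound 4 is therefore expected to give about 3 nM in this assay, estimated to fall between 0.5 nM and 20 nM. That estimate corresponds to an expected step of a 5.0-fold higher number from compound 3 to compound 4 (0.70 log units; beyond the scatter).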

Compound 4, half-maximal inhibitory concentration: 7.6 nM
Estimate against measurement, compound 4: 2.5-fold (0.40 log units) below; the range from low to high includes it.
By their numbers in this assay, from the lowest: compound 3; then compound 4; then compounds 2 and 1 (each within the scatter of the next).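

In this assay phenyl in place of chloro gives a 13-fold higher number from compound 3 to compound 4 (1.10 log units; beyond the scatter) and this is the only step shown that changes the chloro itself, so what the 4-chlorophenyl carries matters, not only where its substituent sits. Compound 4 still keeps part of the advantage of compound 3, with an 11-fold lower number from compound 2 to compound 4 (1.03 log units; beyond the scatter) and a 12-fold lower number from compound 1 to compound 4 (1.07 log units; beyond the scatter) as its steps from the two weaker compounds, so six heavy atoms in place of one lose potency without returning the number to their level. No measurement here explains the loss.

Only chloro and phenyl have been compared at this carbon, so one step cannot show whether the loss comes from removing the chlorine or from adding the ring. A fluoro, an amine or a carboxylic acid in the same place would help separate these two readings.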